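The compounds below may be only part of what the source reports. "The series", "measured", "known", "first", "only" and "open" are said of these compounds alone.

In a functional assay on HCT-116 cells (Homo sapiens) for antiproliferative activity, read by MTT assay (on this read-out higher numbers stand for weaker inhibition and lower numbers for stronger inhibition), compound 1 `CCOC(=O)/C=N/c1cnc(Nc2ccc(N3CCN(C)CC3)cc2)nc1NC(C)C` gives 13600 nM. Compound 2 `CC(C)Nc1nc(Nc2ccc(N3CCN(C)CC3)cc2)ncc1/N=C/c1ccccc1` reaches the limit of the assay, > 100000 nM. Compound 3 `CC(C)Nc1nc(Nc2ccc(N3CCN(C)CC3)cc2)ncc1/N=C/c1cccs1` likewise stands at a limit, > 100000 nM, so its true number is not known; the limit of > 100000 nM in this assay, at which 2 of the 3 values shown sit, tells where it sits. The change to compound 4 `CC(C)Nc1nc(Nc2ccc(N3CCN(C)CC3)cc2)ncc1/N=C/c1ccc(C(F)(F)F)cc1` is 4-(trifluoromethyl)phenyl in place of thiophen-2-yl on a carbon with a double bond to nitrogen. The measured steps that bear on it are an at least 7.3-fold higher number from compound 1 to compound 2 (0.86 log units; beyond the scatter) and an at least 7.3-fold higher number from compound 1 to compound 3 (0.86 log units; beyond the scatter), both ending at the limit, while a step that the two limits leave unreadable from compound 2 to compound 3. Two aryl groups on that carbon have given only limits, so a third aryl group is expected to do the same, and the expected step that the limit leaves unreadable from compound 3 to compound 4 cannot be read with confidence. Compound 4 is estimated at 150000 nM, within a range from 40000 nM to 600000 nM, most probably reported as a limit once more.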

Compound 4, half-maximal inhibitory concentration: 42200 nM
Compound 4: middle estimate off by 3.6-fold (0.55 log units), on the high side, and the stated range covers the measured number.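

In this assay, an aryl group on a carbon with a double bond to nitrogen can give a measured number: 4-(trifluoromethyl)phenyl gives an at least 2.3-fold lower number from compound 3 to compound 4 (0.37 log units; beyond the scatter), and trifluoromethyl in place of hydrogen on an aromatic carbon gives an at least 2.3-fold lower number from compound 2 to compound 4 (0.37 log units; beyond the scatter). Ethoxycarbonyl still holds the lower number, with a 3.1-fold higher number from compound 1 to compound 4 (0.49 log units; beyond the scatter). Both aryl steps start from a limit, so their true size stays unknown: the limit of > 100000 nM in this assay, at which 2 of the 4 values shown sit.

On these data alone, whether a methoxy group or a nitrile on that phenyl ring would move the number remains open. So does whether a carboxylic acid or an amide would match ethoxycarbonyl.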